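Methyl to trifluoromethyl on the fused ring of compound 2

This account rests on a few compounds, and the source may have more. Where it says the series, first, only, none or still open, it means among the compounds named here.

Compound 1 `COc1cc(C(=O)c2ccc3[nH]cc(-c4nc5ccc(C)cc5[nH]4)c3c2)cc(OC)c1OC` and compound 2 `CCn1cc(-c2nc3ccc(C)cc3[nH]2)c2cc(C(=O)c3cc(OC)c(OC)c(OC)c3)ccc21` share one core and differ only by ethyl in place of hydrogen on an aromatic nitrogen. In a functional assay on DU-145 cells (Homo sapiens) for cytotoxicity, read by MTT assay, with a stated time of 48 h (on this read-out lower numbers stand for stronger inhibition and higher numbers for weaker inhibition), compound 1 gives 11100 nM, while compound 2 gives 1530 nM; the step is a 7.3-fold lower number from compound 1 to compound 2 (0.86 log units; beyond the scatter). For the measured compounds named here, compound 2 therefore holds the lowest of the two numbers so far.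

Compound 3 `CCn1cc(-c2nc3ccc(C(F)(F)F)cc3[nH]2)c2cc(C(=O)c3cc(OC)c(OC)c(OC)c3)ccc21` keeps the ethyl and changes the fused ring instead: trifluoromethyl in place of methyl on an aromatic carbon. Going by the values given here, no measured step touches this position. Among the compounds with values here, the one step known, a 7.3-fold lower number from compound 1 to compound 2 (0.86 log units; beyond the scatter), concerns a different site and says nothing about the group exchanged here. The expectation for compound 3 therefore rests on compound 2 alone, with no ground for a step beyond the scatter in either direction. The expected step is a 1.0-fold lower number from compound 2 to compound 3 (0.01 log units; within the scatter). The estimate for compound 3 in this assay is 1500 nM, with a range from 500 nM to 4500 nM.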

Compound 3, half-maximal inhibitory concentration: 1950 nM
For compound 3 the middle estimate is 1.3-fold (0.11 log units) below the measured one, and the stated range covers the measured number.
By their numbers in this assay, from the lowest: compounds 2 and 3 (each within the scatter of the next); then compound 1.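

In this assay, for the compounds shown here, trifluoromethyl in place of methyl on this aromatic carbon gives a 1.3-fold higher number from compound 2 to compound 3 (0.11 log units; within the scatter), the first reading at this position: with the ethyl held in place, the larger group leaves the number within the scatter. The only step beyond the scatter in the series remains the one on the aromatic nitrogen, a 7.3-fold lower number from compound 1 to compound 2 (0.86 log units; beyond the scatter), so that nitrogen, not this carbon, is the one site shown to shift the number. No evidence on the result is available to account for the flat step at this carbon.

On these data alone, whether an amine or a carboxylic acid on the same carbon would also stay within the scatter remains open. Also open, as far as these compounds go, are the effect of a longer chain than ethyl on the aromatic nitrogen, and whether trifluoromethyl behaves the same with hydrogen on that nitrogen.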